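The source may report more compounds than this note shows. Statements on the series, on what has been measured and on what is new or still open speak of the compounds shown alone.

Four compounds share one core. Compound 1 `CCc1ccc(-n2cc(COc3ccc4c(c3)CCC4)nn2)cc1` stands in an ADME assay on HEK293 cells (Homo sapiens) for inhibition, read by MTT assay, with a stated time of 48 h, tested at 25 uM (on this read-out higher numbers stand for more inhibition at the one concentration tested (going by the name of the read-out) and lower numbers for less inhibition), with the entry "not determined" (no result reported), and compound 3 `O=C(Cn1cc(COc2ccc3c(c2)CCC3)nn1)Nc1ccccc1` stands there with the entry "not determined" (no result reported), so for neither of them is a result reported. Among the measured compounds shown here, compound 2 `Cc1cccc(-n2cc(COc3ccc4c(c3)CCC4)nn2)c1` gives 23.4% in this assay, the only number available, so it stands alone with nothing to compare against. Compound 4 `COc1cccc(-n2cc(COc3ccc4c(c3)CCC4)nn2)c1` is the next to be measured. It differs from compound 2 in one place: methoxy in place of methyl on an aromatic carbon, so that 3-methylphenyl becomes 3-methoxyphenyl. For the measured compounds named here, no measured pair shows what such a swap does in this assay. With no comparison to lean on, the expected step is a number 1.6 percentage points higher from compound 2 to compound 4 (within the scatter), a change within the usual scatter and in no firm direction. Compound 4 is therefore expected to give about 25%, with a likely range from 5% to 45%.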

Compound 4, a percentage reported as inhibition, at one concentration (the size of the read-out at that concentration, not a potency): 25.8%
Compound 4: the middle estimate sits 0.8 percentage points below what was measured; low and high end bracket the measured number.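

Methoxy in place of methyl on this aromatic carbon gives a number 2.4 percentage points higher from compound 2 to compound 4 (within the scatter) in this assay. Among the compounds shown here, this is the only measured pair here, and it shows that this one swap, which adds an oxygen and a hydrogen-bond acceptor, does not separate the two compounds on this read-out. Nothing shown gives a cause for this result. Still open, as far as these compounds go, is whether an amine, a carboxylic acid or a longer chain such as ethoxy on this carbon would change the read-out beyond its usual scatter. Also open, from the compounds shown here alone, is whether methoxy would behave alike on another carbon of the ring.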